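Amide variations in a series sitting at the assay limit

The source may report more compounds than this note shows. Statements on the series, on what has been measured and on what is new or still open speak of the compounds shown alone.

Compound 1 `CC(C)=CCCC1=CC[C@@H](C(=O)N(C)C)[C@H](c2ccccc2)C1` carries a dimethylcarbamoyl group on the shared core. In an assay on isolated protein for inhibition of Apoptosis regulator Bcl-2 (Homo sapiens), read by fluorescence polarization, with stated times of 5 min and 10 min (on this read-out higher numbers stand for weaker inhibition and lower numbers for stronger inhibition), compound 1 gives > 23000 nM, which is a limit of the assay and not a number. Its mirror image, compound 3 `CC(C)=CCCC1=CC[C@H](C(=O)N(C)C)[C@@H](c2ccccc2)C1`, also stops at a limit in this assay, where compound 3 gives > 23000 nM. Compound 2 `CC(C)=CCCC1=CC[C@H](C(N)=O)[C@@H](c2ccccc2)C1` has amino in place of dimethylamino on the carbonyl carbon, and in this assay compound 2 gives > 23000 nM, again a limit. For the measured compounds named here, both measured steps, a step that the two limits leave unreadable from compound 1 to compound 3 and a step that the two limits leave unreadable from compound 2 to compound 3, remain unreadable in size and direction because the limit of > 23000 nM in this assay, at which 3 of the 3 values shown sit, leaves no number on either side; for the first of them the fact that compounds 1 and 3 differ only in the configuration as drawn adds only that the two compounds are mirror images. Going by the values given here, nothing among the measured values therefore shows how much a change on the amide nitrogen can move the read-out.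

Compound 4 `CC(C)=CCCC1=CC[C@@H](C(=O)N(C)O)[C@H](c2ccccc2)C1` differs from compound 1 by hydroxy in place of methyl on an amide-type nitrogen. Among the compounds with values here, no measured step covers this change; the closest comparison, amino against dimethylamino on the carbonyl carbon, is itself unreadable. The step that the limit leaves unreadable from compound 1 to compound 4 is therefore expected to stay within the scatter, with the result most likely reported again as a limit. The estimate for compound 4 in this assay is 30000 nM, with a range from 8000 nM to 120000 nM.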

Compound 4, inhibition constant: 2300 nM
Estimate against measurement, compound 4: 13-fold (1.12 log units) above; the whole stated range lies above it.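

In this assay, for the compounds shown here, hydroxy in place of methyl on an amide-type nitrogen gives an at least 10-fold lower number from compound 1 to compound 4 (1.00 log units; beyond the scatter), so a change at this nitrogen can move the read-out, which the earlier compounds could not show. Compound 1 gives > 23000 nM, which is a limit and not a number, so this step fixes only a minimum size. This is the only step in the set with a readable size, and the others cannot be read: the limit of > 23000 nM in this assay, at which 3 of the 4 values shown sit.

On these data alone, whether the hydroxy group itself is needed remains open, since a methoxy group on the same nitrogen would test whether the hydroxy hydrogen matters, and the mirror image of compound 4 would show whether the configuration as drawn affects the read-out. As far as these compounds go, the part played by the methyl group that stays on the nitrogen of compound 4 is also open, and an ethyl group or a longer chain in its place would address that.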